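A Single Inverted Stereocentre at the Assay Limit

The source may hold more compounds than are shown below. What is called first, only, known or untested is meant among the compounds shown, and "the series" means these compounds.

In a functional assay on PC-3 cells (Homo sapiens) for inhibition, read by MTT assay, with a stated time of 24 h (a lower number here means a stronger inhibitor, a higher number a weaker inhibitor), compound 1 (`CCOC1c2cc(OCc3cc(C)cc(C)c3)c(OCc3cc(C)cc(C)c3)cc2CCN1C(=O)OC(C)(C)C`) gives only a limit (> 20000 nM). Compound 2 (`CCC[C@@H]1C[C@@H](O)/C=C\C(CC)[C@H]2c3cc(OCc4ccccc4)c(OCc4ccccc4)cc3CCN12`) offers no number to work with ("not determined" (no result reported)). Compound 3 (`CC[C@@H]1C[C@H](O)C/C=C(/C)[C@H]2c3cc(OCc4ccccc4)c(OCc4ccccc4)cc3CCN12`) also gives only a limit (> 20000 nM). Compound 3 therefore has no number of its own and stands at the limit of > 20000 nM in this assay, at which 2 of the 3 values shown sit, in the data so far.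

Compound 4 (`CC[C@@H]1C[C@@H](O)C/C=C(/C)[C@H]2c3cc(OCc4ccccc4)c(OCc4ccccc4)cc3CCN12`) departs from compound 3 in one respect (the two compounds have the same atoms and bonds and differ only in configuration as drawn: 1 of 4 stereo elements differ; a stereocentre at a saturated ring carbon is drawn R in compound 3 and S in compound 4). Its atoms and bonds are the same, and only a stereocentre at a saturated ring carbon is drawn the other way.

Within the data shown here, no measured pair here shows what such an inversion does in this assay and no direction can be argued from the data. The expectation is therefore for no step beyond the usual scatter, and the assay may well again report only a limit. That expectation rests on the limit of compound 3 (> 20000 nM). The step that this implies is estimated as a number no higher from compound 3 to compound 4 (the limit leaves the size open) and should be read as a rough expectation, since one end of it is not a true number. For compound 4 the estimated value is 20000 nM with a range of 8000 nM to 40000 nM expected.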

Compound 4, half-maximal inhibitory concentration: > 20000 nM
Compound 4 gave a limit, no number (the forecaster's own chance of this, stated with the estimate: 75%); the middle value lies on the limit itself.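

Among these compounds, compound 3 and compound 4 both give only a limit in this assay, so no step between them can be read, and inverting the stereocentre at a saturated ring carbon has no measurable size here. The compounds shown leave open whether either configuration at that carbon would give a true number in this assay: the limit of > 20000 nM in this assay, at which 3 of the 4 values shown sit.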